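Swapping the Pyridine Arm for an Acetylated Pyrazole

A few compounds are considered here, and "the series" means these few. Any claim that something is new, unique, unknown or untested is made for them only; others in the source may bear on it.

Measured so far:
- compound 1 `CNC(=O)N1CCCc2ccc(NC(=O)c3ccc(-c4ccn(S(C)(=O)=O)n4)cc3)cc21`: 8.81%
- compound 2 `CNC(=O)N1CCCc2ccc(NC(=O)c3ccc(-c4cccnc4)cc3)cc21`: 62.5%

In a functional assay on MV4-11 cells (Homo sapiens) for antiproliferative activity, with a stated time of 6 days, tested at 1.56 uM (a lower number here means a weaker effect, a higher number a stronger effect of the compound at the concentration tested), compound 2 gives 62.5%, the higher of the two numbers at hand, while compound 1 gives 8.81%. Going by the values given here, the one step measured is a number 53.7 percentage points higher from compound 1 to compound 2 (beyond the scatter), so exchanging an N-substituted pyrazole for a pyridine here made a large difference.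

Compound 3 `CNC(=O)N1CCCc2ccc(NC(=O)c3ccc(-c4cnn(C(C)=O)c4)cc3)cc21` has not yet been measured. It differs from compound 2 in one place: 1-acetyl-1H-pyrazol-4-yl in place of pyridin-3-yl on an aromatic carbon, on an aromatic carbon of a six-membered aromatic ring of carbon only, para to a large group. This change runs in the opposite sense to the measured step: a pyridin-3-yl gives way to a pyrazole carrying a substituent on its nitrogen, as in compound 1. Because of a number 53.7 percentage points higher from compound 1 to compound 2 (beyond the scatter), a drop beyond the scatter is expected, although the acetyl group and the altered attachment point leave room for a smaller fall. Compound 3 is therefore expected to reach about 25% in this assay, within 5% to 55%, a step of a number 37.5 percentage points lower from compound 2 to compound 3 (beyond the scatter).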

Compound 3, a percentage reported as inhibition, at one concentration (the size of the read-out at that concentration, not a potency): 23.9%
Compound 3: the middle estimate sits 1.1 percentage points above what was measured; the range from low to high includes it.
By their numbers in this assay, from the lowest: compound 1; then compound 3; then compound 2.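

At this position, on an aromatic carbon para to a large group, a second pyrazole carrying a substituent on its nitrogen also falls well short of the pyridin-3-yl: in this assay the change gives a number 38.6 percentage points lower from compound 2 to compound 3 (beyond the scatter). The two pyrazoles are not interchangeable either, as 1-acetyl-1H-pyrazol-4-yl in place of 1-(methylsulfonyl)-1H-pyrazol-3-yl gives a number 15.1 percentage points higher from compound 1 to compound 3 (beyond the scatter), a modest gain that shows the details of the arm still count even when the ring is a pyrazole. No measurement at hand explains either step.

The pyrazole arms differ in two ways at once, in the group on the nitrogen and in the ring carbon that carries the attachment, so the shift between them cannot be assigned to either difference alone. As far as these compounds go, it also remains open whether a simpler 1-methyl-1H-pyrazol-4-yl, a pyrazole with a bare ring nitrogen, or a pyridine bearing an amine would stay close to the pyridin-3-yl or fall toward the two pyrazoles.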